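Demethylation at the Urea Pyrazole: Expected Growth Inhibition

The compounds below may be only part of what the source reports. "The series", "measured", "known", "first", "only" and "open" are said of these compounds alone.

Compound 1 `O=C(Nc1cccc(-n2cc(-c3ccncc3)c(-c3ccc(Cl)c(O)c3)n2)c1)Nc1cccc(C(F)(F)F)c1`: > 32500 nM
Compound 2 `COc1cc(-c2nn(-c3cccc(NC(=O)Nc4ccc(Cl)c(Cl)c4)c3)cc2-c2ccncc2)ccc1Cl`: > 50000 nM

In a functional assay on A549 cells (Homo sapiens) for inhibition, read by sulforhodamine B assay, with a stated time of 48 h (on this read-out lower numbers stand for stronger inhibition of growth and higher numbers for weaker inhibition of growth), compound 2 gives > 50000 nM, which is a limit of the assay and not a number, namely (the limit of > 50000 nM in this assay, at which 1 of the 2 values shown sits). Compound 1, which carries the hydroxy group already, likewise sits at a limit, (the limit of > 32500 nM in this assay, at which 1 of the 2 values shown sits). Compound 3 `O=C(Nc1cccc(-n2cc(-c3ccncc3)c(-c3ccc(Cl)c(O)c3)n2)c1)Nc1ccc(Cl)c(Cl)c1` differs from compound 2 by hydrogen in place of methyl on an oxygen on an aromatic ring. Within the data shown here, no measured step covers this change; since compound 1 with the same hydroxy group also sits at a limit, no move beyond the scatter is expected, and the step that the limit leaves unreadable from compound 2 to compound 3 is estimated to be small or none. Compound 3 is therefore expected to give 60000 nM, between 20000 nM and 150000 nM, most likely again reported only as a limit.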

Compound 3, concentration for total growth inhibition: > 32500 nM
Compound 3: a limit, no number; the forecaster's own chance of this, stated with the estimate: 85%; the middle value lies beyond the limit too.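

Among these compounds, compound 1, compound 2 and compound 3 all sit at limits, so no step from compound 2 or compound 1 to compound 3 can be read. On these data alone, whether either change alters growth inhibition in this assay remains open.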